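Swapping one fused ring for another: cytotoxicity outlook

This account rests on a few compounds, and the source may have more. Where it says the series, first, only, none or still open, it means among the compounds named here.

In an ADME assay on BJ cells (Homo sapiens) for cytotoxicity, with a stated time of 72 h (on this read-out lower numbers stand for an effect already at smaller amounts and higher numbers for an effect only at larger amounts of compound), compound 1 `O=C(Nc1ccc(F)c(-c2nc3ccccc3o2)c1)c1cc([N+](=O)[O-])ccc1Cl` gives > 25000 nM, which is a limit of the assay rather than a number. Compound 2 `O=C(Nc1ccc(F)c(-c2nc3ccccc3s2)c1)c1cc([N+](=O)[O-])ccc1Cl` gives > 25000 nM, again a limit. Compound 3 `Cc1ccc(-c2nc3ccccc3s2)cc1NC(=O)c1cc([N+](=O)[O-])ccc1Cl` gives > 14000 nM, also a limit. The change 1,3-benzoxazol-2-yl in place of 1,3-benzothiazol-2-yl on an aromatic carbon yields a step that the two limits leave unreadable from compound 2 to compound 1. Compound 4 `Cc1ccc(-c2nc3ccccc3o2)cc1NC(=O)c1cc([N+](=O)[O-])ccc1Cl` differs from compound 3 by 1,3-benzoxazol-2-yl in place of 1,3-benzothiazol-2-yl on an aromatic carbon; the difference between the two cores is not broken down here. Around the place, compound 1 carries the new ring ortho to a fluoro group (1 heavy atom) and meta to a large group, whereas compound 4 carries it meta to a large group and para to a methyl group (1 heavy atom), so this is the same kind of change, not the same. The step is expected to be a step that the limit leaves unreadable from compound 3 to compound 4, because compound 3 sits at the limit of > 14000 nM in this assay, at which 1 of the 3 values shown sits, while compound 1 and compound 2 sit at the limit of > 25000 nM in this assay, at which 2 of the 3 values shown sit. Compound 4 is therefore expected to give 30000 nM, between 14000 nM and 70000 nM.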

Compound 4, half-maximal effective concentration: > 14000 nM
Compound 4: only a limit was reported (the forecaster's own chance of this, stated with the estimate: 85%); the middle value is on the limit's open side.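

For the compounds shown here, compound 3 and compound 4 each give only a limit of the assay, and no step between them can be read. As far as these compounds go, whether 1,3-benzoxazol-2-yl in place of 1,3-benzothiazol-2-yl changes the result in this assay at all stays open.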